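From Pyrrolidin-1-yl to 2,3-Dihydro-1H-indol-1-yl on the Thiocarbonyl

The compounds below may be only part of what the source reports. "The series", "measured", "known", "first", "only" and "open" are said of these compounds alone.

Measured so far:
compound 1 `Nc1ccccc1NC(=O)c1ccc(CSC(=S)N2CCc3cc([N+](=O)[O-])ccc32)cc1`: 32.6%
compound 2 `CN(C(=S)SCc1ccc(C(=O)Nc2ccccc2N)cc1)c1cccnc1`: 16%
compound 3 `Nc1ccccc1NC(=O)c1ccc(CSC(=S)N2CCCC2)cc1`: 51.3%

All three share one core and differ only in the group on the thiocarbonyl carbon. In a functional assay on HeLa cells (Homo sapiens) for antiproliferative activity, read by CCK-8 assay, with a stated time of 72 h, tested at 2 uM (a higher number here means a stronger effect of the compound at the concentration tested, a lower number a weaker effect), compound 3 stands highest of the three numbers: compound 1 sits below it beyond the scatter, and compound 2 lies furthest below. Within the data shown here, the one measured step is a number 35.3 percentage points higher from compound 2 to compound 3 (beyond the scatter), a large gain.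

Compound 4 `Nc1ccccc1NC(=O)c1ccc(CSC(=S)N2CCc3ccccc32)cc1` is the next variation: 2,3-dihydro-1H-indol-1-yl in place of pyrrolidin-1-yl on a thiocarbonyl carbon. Among the measured compounds shown here, no measured step shows this exact exchange. For the measured compounds named here, compound 1 carries a related group on the same thiocarbonyl carbon, bearing a nitro substituent, and gives a number well below compound 3, so the ring-fused group has so far gone with a lower value; the only step measured, from compound 2 to compound 3, concerns a different exchange. Compound 4 is therefore expected to fall between compound 1 and compound 3, at 38% with a range from 18% to 58%, which means an estimated drop a number 13.3 percentage points lower from compound 3 to compound 4 (beyond the scatter).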

Compound 4, a percentage reported as inhibition, at one concentration (the size of the read-out at that concentration, not a potency): 38%
The estimate for compound 4 equals the measured number at the digits printed; the range from low to high includes it.
By their numbers in this assay, from the lowest: compound 2; then compounds 1 and 4 (each within the scatter of the next); then compound 3.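

In this assay, 2,3-dihydro-1H-indol-1-yl in place of pyrrolidin-1-yl on the thiocarbonyl carbon gives a number 13.3 percentage points lower from compound 3 to compound 4 (beyond the scatter), so adding a six-membered aromatic ring of carbon only to the five-membered ring costs a modest part of the effect. The same group still compares well with methyl(pyridin-3-yl)amino, with a number 22 percentage points higher from compound 2 to compound 4 (beyond the scatter) as the step. Hydrogen in place of nitro on the aromatic carbon gives a number 5.4 percentage points higher from compound 1 to compound 4 (within the scatter), so the lower number of compound 1 goes with the ring-fused group and not with its nitro group.

Nothing measured here bears on what lies behind these steps. Also open, from the compounds shown here alone, is whether piperidin-1-yl or morpholin-4-yl on the same thiocarbonyl carbon would match compound 3, and whether a methoxy group in place of the nitro group would separate from compound 4.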